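The source may hold more compounds than are shown below. What is called first, only, known or untested is meant among the compounds shown, and "the series" means these compounds.

Of the compounds shown here, three built on the shared core have been measured in a physicochemical assay for solubility, measured as kinetic solubility; on this read-out lower numbers stand for lower solubility and higher numbers for higher solubility. Compound 1 (`Cc1cnc(NC(=O)c2cc(Oc3cnc(C(=O)N(C)C)cn3)c3cn(C)nc3c2)cn1`) gives 192000 nM, compound 2 (`Cc1cnc(NC(=O)c2cc(Oc3ccc(C(=O)N(C)C)cc3)c3cn(C)nc3c2)cn1`) gives 351000 nM, and compound 3 (`Cc1cnc(NC(=O)c2cc(Oc3ccc(S(C)(=O)=O)cc3)c3cn(C)nc3c2)cn1`) gives 454000 nM. The numbers of compound 2 and compound 3 lie within the scatter of each other, while the number of compound 3 stands higher than that of compound 1, beyond the scatter.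

Compound 4 (`CCS(=O)(=O)c1ccc(Oc2cc(C(=O)Nc3cnc(C)cn3)cc3nn(C)cc23)cc1`) has not yet been measured. It differs from compound 3 by methyl in place of hydrogen on a saturated chain carbon bound to a sulfonyl sulfur, so that methylsulfonyl becomes ethylsulfonyl.

Among the measured compounds shown here, only one measured step bears on this group, and only indirectly: a 1.3-fold higher number from compound 2 to compound 3 (0.11 log units; within the scatter), with methylsulfonyl in place of dimethylcarbamoyl on an aromatic carbon. That step stayed within the scatter. For the measured compounds named here, no measured pair shows a change in the sulfonyl chain itself, so the evidence is thin and no shift beyond the scatter is expected in either direction.

The expected size of the change is a 1.2-fold lower number from compound 3 to compound 4 (0.07 log units; within the scatter), which would lie within the scatter. In this assay the estimate for compound 4 is 390000 nM, with an expected range from 200000 nM to 640000 nM.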

Compound 4, solubility: 69000 nM
Estimate against measurement, compound 4: 5.7-fold (0.75 log units) above; the measured number lies below the stated range.
By their numbers in this assay, from the lowest: compound 4; then compounds 1, 2 and 3 (each within the scatter of the next, the first and the last beyond it).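

In this assay, the sulfonyl chain proves to be a position where a small change can carry a large step: methyl in place of hydrogen gives a 6.6-fold lower number from compound 3 to compound 4 (0.82 log units; beyond the scatter) and so moves the number beyond the scatter, whereas the earlier exchange of dimethylcarbamoyl for methylsulfonyl gave only a 1.3-fold higher number from compound 2 to compound 3 (0.11 log units; within the scatter) and stayed within it. The exchange of dimethylcarbamoyl for ethylsulfonyl likewise gives a 5.1-fold lower number from compound 2 to compound 4 (0.71 log units; beyond the scatter) in this assay, so the methylsulfonyl and ethylsulfonyl groups do not behave alike here, even though both are sulfonyl groups. Nothing measured here accounts for the size of these steps.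

On these data alone, it remains open whether the number keeps dropping as the chain grows or whether ethyl is a special case, which a longer chain such as propyl, a branched isopropyl or a chain ending in a hydroxyl or an amine could settle. As far as these compounds go, it is equally open whether methylsulfonyl to ethylsulfonyl gives a step of this size on the aromatic ring that carries the substituent in compound 1.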